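The source may report more compounds than this note shows. Statements on the series, on what has been measured and on what is new or still open speak of the compounds shown alone.

Measured in an assay on HEK293 cells for inhibition of acid ceramidase (Homo sapiens), with a stated time of 10 min; a higher number here means a weaker inhibitor, a lower number a stronger inhibitor:

compound 1 `O=C(NCCCc1ccccc1)n1c(=O)oc2ccccc21`: 55 nM
compound 2 `O=C(NCCCCCc1ccccc1)n1c(=O)oc2ccccc21`: 54 nM
compound 3 `O=C(NCCCCc1ccc(F)cc1)n1c(=O)oc2ccccc21`: 75 nM

Compound 3 shows the highest of the three numbers in this assay, but both neighbours lie within the scatter: the step of a 1.4-fold higher number from compound 1 to compound 3 (0.13 log units; within the scatter) and the step of a 1.4-fold higher number from compound 2 to compound 3 (0.14 log units; within the scatter) are each too small to count as a change, as is the step of a 1.0-fold lower number from compound 1 to compound 2 (0.01 log units; within the scatter). Across the three compounds the chain between the carbamoyl nitrogen and the aryl ring has been lengthened and the ring fluorinated without any move beyond the scatter.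

Compound 4 `O=C(NCCCCc1cccs1)n1c(=O)oc2ccccc21` carries the change (thiophen-2-yl in place of 4-fluorophenyl on a saturated chain carbon, four bonds along the chain from an amide-type nitrogen). The step that bears on it most directly is a 1.4-fold higher number from compound 2 to compound 3 (0.14 log units; within the scatter), which exchanges the aryl group at the same chain position and stays within the scatter; the step of a 1.4-fold higher number from compound 1 to compound 3 (0.13 log units; within the scatter) likewise alters the terminal ring without a real shift. Nothing measured here separates one terminal aromatic ring from another, so for compound 4 in this assay the expected step of a 1.3-fold lower number from compound 3 to compound 4 (0.10 log units; within the scatter) is none beyond the scatter, with a slight lean toward the middle of the series.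

Compound 4 is therefore estimated at 60 nM, within a range of 25 nM to 150 nM.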

Compound 4, half-maximal inhibitory concentration: 37 nM
Beside the measured number, compound 4's estimate is 1.6-fold (0.21 log units) above it; the measured number falls inside the stated range.
By their numbers in this assay, from the lowest: compounds 4, 2, 1 and 3 (each within the scatter of the next, the first and the last beyond it).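

In this assay, thiophen-2-yl in place of 4-fluorophenyl, on a saturated chain carbon, four bonds along the chain from an amide-type nitrogen, gives the only step among these compounds that lies beyond the scatter, a 2.0-fold lower number from compound 3 to compound 4 (0.31 log units; beyond the scatter), so the terminal ring at this position is not wholly indifferent, though the step is modest. Its reach is narrow: a 1.5-fold lower number from compound 2 to compound 4 (0.16 log units; within the scatter) and a 1.5-fold lower number from compound 1 to compound 4 (0.17 log units; within the scatter) both stay within the scatter, so compound 4 separates from compound 3 alone and not from the two compounds with an unsubstituted phenyl ring. No supporting data are at hand to account for the step.

Open, from the compounds shown here alone, is whether the step follows the entry of the sulfur-containing five-membered ring or the departure of the fluorine, a question that a plain phenyl, a thiophen-3-yl or a furan-2-yl at this same chain carbon would address. Also open, going by these compounds, is how thiophen-2-yl reads on a shorter or longer chain, and how a terminal amine or carboxylic acid in place of the ring would read in this assay.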